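The compounds below may be only part of what the source reports. "The series", "measured", "known", "first", "only" and "open" are said of these compounds alone.

Measured compounds and their values in a functional assay on HEK293 cells for agonist activity at D(4) dopamine receptor (Homo sapiens), read by FLIPR; a higher number here means that more compound is needed for the effect, a lower number that less compound is needed:

compound 1, `O=C(NCN1CCC(c2cccc[n+]2[O-])CC1)c1cnccc1Cl`, gives 1290 nM
compound 2, `O=C(CN1CCC(c2cccc[n+]2[O-])CC1)Nc1ccccc1F`, gives 270 nM

Compound 1 stands at the higher of the two numbers in this assay; compound 2 sits at the lower number, and the gap between them is beyond the usual scatter. For the measured compounds named here, the two share the core of compound 1 but differ in several places at once, so the two values show only that compound 2 needs less compound for the effect than compound 1, without pointing to any single cause.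

Compound 3, `O=C(NCN1CCC(c2cccc[n+]2[O-])CC1)c1cc(Cl)cc(Cl)c1`, is not yet measured in this assay. It differs from compound 1 in one place: 3,5-dichlorophenyl in place of 4-chloropyridin-3-yl on a carbonyl carbon. Going by the values given here, the 4-chloropyridin-3-yl is the only group that leaves, and the 3,5-dichlorophenyl enters on the same carbonyl carbon, so the rest of compound 1 is untouched.

Among the compounds with values here, no pair of measured compounds differing in one place is available to calibrate this change, so the expectation rests on compound 1 alone. A modest step towards a lower number is expected from compound 1 to compound 3, a 1.8-fold lower number from compound 1 to compound 3 (0.27 log units; within the scatter), but a step of either direction within the scatter would not surprise. Compound 3 is estimated at 700 nM, with a range from 200 nM to 2500 nM.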

Compound 3, half-maximal effective concentration: 45 nM
Estimate against measurement, compound 3: 16-fold (1.19 log units) above, and the stated range ends above it.
By their numbers in this assay, from the lowest: compound 3; then compound 2; then compound 1.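

The group on this carbonyl carbon proves highly consequential in this assay, where 3,5-dichlorophenyl in place of 4-chloropyridin-3-yl gives a 29-fold lower number from compound 1 to compound 3 (1.46 log units; beyond the scatter) with the rest of compound 1 untouched. For the compounds shown here, the earlier compounds differed in several places at once and gave no single-change step, so this is the first evidence that one exchange at this position can, on its own, produce a large shift. The exchange is composite, however, since the ring nitrogen leaves and the chlorine count changes together, and no measurement shown bears on what lies behind the step.

Still open, on these data alone, is whether the step follows the loss of the ring nitrogen or the two chlorines of the entering group; an unsubstituted phenyl, a phenyl with a single chlorine or a 3,5-dimethylphenyl on the same carbonyl carbon would help to separate these readings. Also open, as far as these compounds go, is whether the 3,5-dichlorophenyl keeps this effect with a longer chain joining the amide nitrogen to the shared core.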